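Adding a Second Methoxy to the Aryl Ring of Compound 3

A few compounds are considered here, and "the series" means these few. Any claim that something is new, unique, unknown or untested is made for them only; others in the source may bear on it.

Compound 3 `COc1ccc(-c2cc(C(=O)Nc3nc4ccccc4s3)nc3cc(-c4ccccc4)nn23)cc1` is the most potent of the three measured compounds in a functional assay on DU-145 cells (Homo sapiens) for cytotoxicity, read by MTT assay, with a stated time of 48 h (a higher number here means a weaker inhibitor, a lower number a stronger inhibitor), where compound 3 gives 2950 nM. Compound 1 `COc1ccc(-c2cc(C(=O)Nc3nc4ccc(Cl)cc4s3)nc3cc(-c4ccccc4)nn23)cc1OC` gives 9330 nM in this assay, and compound 2 `COc1ccc2nc(NC(=O)c3cc(-c4ccc(OC)c(OC)c4)n4nc(-c5ccccc5)cc4n3)sc2c1` gives 14000 nM; both carry the 3,4-dimethoxyphenyl group, while compound 3 carries 4-methoxyphenyl and an unsubstituted benzothiazole. Going by the values given here, the only single-point step among the measured compounds, a 1.5-fold higher number from compound 1 to compound 2 (0.18 log units; within the scatter), concerns the benzothiazole and not the aryl ring, so no measured step bears directly on the change now considered.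

Compound 4 `COc1ccc(-c2cc(C(=O)Nc3nc4ccccc4s3)nc3cc(-c4ccccc4)nn23)cc1OC` arises from compound 3 by methoxy in place of hydrogen on an aromatic carbon. Among the compounds with values here, compound 1 and compound 2 differ from compound 3 in two places each, so their values show only that the dimethoxy compounds sit weaker than compound 3 without isolating the methoxy effect. A modest weakening is expected, so for the step of a 1.7-fold higher number from compound 3 to compound 4 (0.23 log units; within the scatter) is estimated. Compound 4 is therefore expected to give about 5000 nM in this assay, within a range of 2000 nM to 14000 nM.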

Compound 4, half-maximal inhibitory concentration: 19100 nM
For compound 4 the middle estimate is 3.8-fold (0.58 log units) below the measured one; the measured number lies above the stated range.
By their numbers in this assay, from the lowest: compound 3; then compounds 1, 2 and 4 (each within the scatter of the next, the first and the last beyond it).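

In this assay the change from 4-methoxyphenyl to 3,4-dimethoxyphenyl can now be read on its own, and the added methoxy, ortho to a methoxy group, gives a 6.5-fold higher number from compound 3 to compound 4 (0.81 log units; beyond the scatter) on a compound otherwise unchanged. Going by these compounds alone, this single change therefore weakens the compound clearly, which the earlier compounds could not show. With 3,4-dimethoxyphenyl held constant, hydrogen in place of methoxy gives a 1.4-fold higher number from compound 2 to compound 4 (0.13 log units; within the scatter) while hydrogen in place of chloro gives a 2.0-fold higher number from compound 1 to compound 4 (0.31 log units; beyond the scatter) as a further comparison, so these two changes elsewhere on the molecule are both far smaller than the step from the added methoxy. Nothing at hand explains the size of that step.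

The compounds shown leave open whether the loss is specific to methoxy or would also follow from a hydroxyl, a fluorine or a longer ethoxy chain on the same carbon. They also leave open whether the step would keep its size with chloro or methoxy present elsewhere on the molecule.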